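Phenyl to methyl on the chain: compound 4 expected

A few compounds are considered here, and "the series" means these few. Any claim that something is new, unique, unknown or untested is made for them only; others in the source may bear on it.

Three measured compounds share one core and differ only in the saturated chain attached to it. Compound 1 `Fc1cccc(-c2nn3c(Cc4ccccc4)nnc3s2)c1` gives 33% in an assay for inhibition of histone-lysine N-methyltransferase, H3 lysine-79 specific (Homo sapiens), with stated times of 15 min and 120 min, tested at 50 uM; on this read-out lower numbers stand for less inhibition and higher numbers for more inhibition at the one concentration tested (going by the name of the read-out). Compound 2 `CCc1nnc2sc(-c3cccc(F)c3)nn12` gives 13% in this assay, and compound 3 `Fc1cccc(-c2nn3c(CCc4ccccc4)nnc3s2)c1` gives 18% in this assay. Compound 3 thus stands second highest of the three; it sits nearest to compound 2, a gap within the scatter, and furthest from compound 1, a gap beyond it. The recorded steps are a number 20 percentage points lower from compound 1 to compound 2 (beyond the scatter), a number 15 percentage points lower from compound 1 to compound 3 (beyond the scatter) and a number 5 percentage points higher from compound 2 to compound 3 (within the scatter).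

Compound 4 `CCCc1nnc2sc(-c3cccc(F)c3)nn12` is not yet measured. It differs from compound 3 by methyl in place of phenyl on a saturated chain carbon, two bonds along the chain from an aromatic carbon. Among the measured compounds shown here, the one measured step at this same place on the chain, a number 5 percentage points higher from compound 2 to compound 3 (within the scatter), lay within the scatter; the two larger steps, a number 20 percentage points lower from compound 1 to compound 2 (beyond the scatter) and a number 15 percentage points lower from compound 1 to compound 3 (beyond the scatter), concern a different place on the chain and guide the expectation only loosely. Accordingly no step beyond the scatter in this assay is expected, the estimated step being a number 3 percentage points lower from compound 3 to compound 4 (within the scatter). Compound 4 is estimated at 15%, with a range from 4% to 28%.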

Compound 4, a percentage reported as inhibition, at one concentration (the size of the read-out at that concentration, not a potency): 35%
For compound 4 the middle estimate is 20 percentage points below the measured one, and the stated range ends below it.
By their numbers in this assay, from the lowest: compounds 2 and 3 (each within the scatter of the next); then compounds 1 and 4 (each within the scatter of the next).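

At the saturated chain carbon two bonds along from an aromatic carbon, phenyl is not the better group: methyl in its place gives a number 17 percentage points higher from compound 3 to compound 4 (beyond the scatter) in this assay, and methyl in place of hydrogen at the same carbon gives a number 22 percentage points higher from compound 2 to compound 4 (beyond the scatter). A terminal phenyl is also not required to reach the upper level of this small set, since ethyl in place of phenyl on the chain carbon bound to an aromatic carbon gives a number 2 percentage points higher from compound 1 to compound 4 (within the scatter). The effect of phenyl to methyl depends on where the change falls on the chain, and it reverses in direction between the two places: the same change on two cores in this assay, a number 20 percentage points lower (beyond the scatter) from compound 1 to compound 2 and a number 17 percentage points higher (beyond the scatter) from compound 3 to compound 4, 37 percentage points apart, beyond the scatter of two such steps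

Going by these compounds, whether a longer chain would hold or raise the number of compound 4 remains open, as does the effect of an amine or a carboxylic acid at the chain end. On these data alone, with a single concentration as the read-out, the potency of compound 1 and compound 4 also remains open.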